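Clearance notes: fluoro added to compound 1's fluorobenzyl

This account rests on a few compounds, and the source may have more. Where it says the series, first, only, none or still open, it means among the compounds named here.

Three compounds of the series have numbers in an ADME assay on liver (Mus musculus) for metabolic stability, read by LC-MS, using microsomes and NADPH, with stated times of 5 min and 30 min, tested at 1 uM; a lower number here means slower removal, a higher number faster removal of the compound. Compound 1 `Nc1c(C(=O)O)cnn1-c1ccc(CN(Cc2ccc(F)cc2)Cc2ccc(Cl)cc2)cc1` gives 2.1 mL.min-1.g-1 in this assay. Compound 2 `COc1ccc(-c2noc(C(Cc3ccc(-n4ncc(C(=O)O)c4N)cc3)c3ccc(F)cc3)n2)cc1` gives 1.5 mL.min-1.g-1, and compound 3 `COc1ccc(C(Cc2ccc(-n3ncc(C(=O)O)c3N)cc2)c2nc(-c3cccc(F)c3)no2)cc1` gives 1.3 mL.min-1.g-1. Compound 1 has the highest of the three numbers, but its gaps to compound 2 and to compound 3 both lie within the scatter of repeated measurements, so the three read as one level rather than an order.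

Compound 4 `Nc1c(C(=O)O)cnn1-c1ccc(CN(Cc2ccc(Cl)cc2)Cc2ccc(F)c(F)c2)cc1` is not yet measured in this assay. It differs from compound 1 by fluoro in place of hydrogen on an aromatic carbon, turning the 4-fluorobenzyl into a 3,4-difluorobenzyl. Within the data shown here, no measured pair shows a change of this kind, so there is no step to lean on. Given the small size of the change, the expected step from compound 1 to compound 4 is a 1.2-fold lower number from compound 1 to compound 4 (0.07 log units; within the scatter), no more than the scatter, with no clear direction. For compound 4 the estimated value in this assay is 1.8 mL.min-1.g-1, within a range of 0.9 mL.min-1.g-1 to 3.6 mL.min-1.g-1.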

Compound 4, intrinsic clearance in microsomes: 1.2 mL.min-1.g-1
For compound 4 the middle estimate is 1.5-fold (0.18 log units) above the measured one; the measured number falls inside the stated range.
By their numbers in this assay, from the lowest: compounds 4, 3, 2 and 1 (each within the scatter of the next).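

The series now has its first step that differs in one place: in this assay, going from 4-fluorobenzyl to 3,4-difluorobenzyl gives a 1.8-fold lower number from compound 1 to compound 4 (0.24 log units; within the scatter). Among these compounds, a second fluoro at this position, ortho to a fluoro group and meta to a large group, therefore makes no change here that can be told apart from repeat scatter, and compound 4 stays at the one level shared by the series so far. No measurement is available that would explain this result.

This is a single step on a single ring, so it does not show whether a larger group at the same position, such as trifluoromethyl or a nitrile, would move the clearance beyond the scatter. On these data alone, whether fluoro on the other benzyl group would read the same also remains open.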